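A longer chain on compound 3

This account rests on a few compounds, and the source may have more. Where it says the series, first, only, none or still open, it means among the compounds named here.

Measured in a functional assay, with a stated time of 10 min (on this read-out lower numbers stand for stronger inhibition and higher numbers for weaker inhibition), so far:
compound 1 `CCCCCCCCCCCCCCOc1cc(OC)c(Br)cc1C(C)=O` gives 13200000 nM
compound 2 `CCCCOc1cc(OC)ccc1C(C)=O` gives 57200000 nM
compound 3 `CCCCCCCCOc1cc(OC)ccc1C(C)=O` gives 69400000 nM

Compound 3 sits level with compound 2 within the scatter, while compound 1 reads a clearly lower number than either. The next compound to be tested is compound 4 `CCCCCCCCCCCCCCOc1cc(OC)ccc1C(C)=O` which differs from compound 3 by hexyl in place of hydrogen on a saturated chain carbon, eight bonds along the chain from an oxygen on an aromatic ring with the rest of the structure unchanged.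

Among the measured compounds shown here, only one measured step is of the same kind, the earlier extension of the chain. It amounts to a 1.2-fold higher number from compound 2 to compound 3 (0.08 log units; within the scatter) and so gives no sign that chain length moves this assay at all. Compound 1 carries the chain that compound 4 would carry, but it also has a bromine on the core. For the measured compounds named here, for compound 1 the value of 13200000 nM therefore cannot be assigned to the chain alone, since no measured pair separates the two features. It gives only a slight reason to lean towards lower numbers.

The expected change is a 1.5-fold lower number from compound 3 to compound 4 (0.19 log units; within the scatter) and so no step beyond the scatter is expected. For compound 4 the estimated value is 45000000 nM with an expected range from 15000000 nM to 110000000 nM in this assay.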

Compound 4, half-maximal inhibitory concentration: 57000000 nM
For compound 4 the middle estimate is 1.3-fold (0.10 log units) below the measured one; low and high end bracket the measured number.
By their numbers in this assay, from the lowest: compound 1; then compounds 4, 2 and 3 (each within the scatter of the next).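

Adding hexyl to the chain gives a 1.2-fold lower number from compound 3 to compound 4 (0.09 log units; within the scatter) in this assay, and with a 1.2-fold higher number from compound 2 to compound 3 (0.08 log units; within the scatter) this shows that, across compounds 2, 3 and 4, neither extension of the chain moves the read-out beyond the scatter. Among the compounds shown here, compound 4 also forms the first pair that separates the two features of compound 1: hydrogen in place of bromo on an aromatic carbon gives a 4.3-fold higher number from compound 1 to compound 4 (0.64 log units; beyond the scatter), which lies beyond the scatter, so the clearly lower number of compound 1 goes with the bromo and not with the long chain. No measurement is available that explains either step.

The compounds shown leave open whether the bromo gives a step of similar size on the shorter butyl-bearing or octyl-bearing chains, since it appears only once, and whether chloro or a nitrile at the same aromatic carbon would do the same. They also leave open whether an amine or a carboxylic acid at the far end of the chain would move the read-out where plain extension of the chain did not.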